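The source may hold more compounds than are shown below. What is called first, only, known or untested is meant among the compounds shown, and "the series" means these compounds.

Among the compounds with values here, in an in vitro assay on BHK cells for inhibition of Glucagon receptor (Homo sapiens) (on this read-out lower numbers stand for stronger inhibition and higher numbers for weaker inhibition), compound 2 `CC(C)(C)[C@H]1CC[C@H](N(Cc2ccc(C(=O)NCCC(=O)O)cc2)C(=O)Nc2ccc(Cl)c(Cl)c2)CC1` gives 226 nM, the lowest of the two numbers measured so far. Within the data shown here, the only other measured compound is compound 1 `CC(C)(C)[C@H]1CC[C@H](N(Cc2ccc(C(=O)NCCC(=O)O)cc2)C(=O)Nc2ccc(C#N)cc2)CC1`, which in this assay gives 1050 nM; the step of a 4.6-fold lower number from compound 1 to compound 2 (0.67 log units; beyond the scatter) shows that exchanging the aryl group on the amide-type nitrogen shifts the read-out by a modest amount.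

Compound 3 `CC(C)c1ccc(NC(=O)N(Cc2ccc(C(=O)NCCC(=O)O)cc2)[C@H]2CC[C@H](C(C)(C)C)CC2)cc1` has not yet been measured in this assay. It differs from compound 2 in one place: 4-isopropylphenyl in place of 3,4-dichlorophenyl on an amide-type nitrogen. Among the measured compounds shown here, no measured step shows this particular exchange, so the expectation rests only on the single step from compound 1 to compound 2, which shows that changes of the aryl group at this position move the number by a modest amount and can go in either direction. Compound 3 is therefore expected to stay within a modest distance of compound 2, most likely giving a somewhat higher number, an estimated step of a 2.0-fold higher number from compound 2 to compound 3 (0.30 log units; within the scatter). The estimate for compound 3 in this assay is 450 nM, with a range from 120 nM to 1600 nM.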

Compound 3, half-maximal inhibitory concentration: 35 nM
The estimate for compound 3 lay 13-fold (1.11 log units) above the measured number, outside the stated range (below it).
By their numbers in this assay, from the lowest: compound 3; then compound 2; then compound 1.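

In this assay, the aryl group on the amide-type nitrogen proves able to move the number further than the first pair suggested: 4-isopropylphenyl in place of 3,4-dichlorophenyl gives a 6.5-fold lower number from compound 2 to compound 3 (0.81 log units; beyond the scatter) and so places compound 3 lowest of the three, with both of its steps beyond the scatter. Set against the nitrile-bearing aryl group, isopropyl in place of cyano on an aromatic carbon gives a 30-fold lower number from compound 1 to compound 3 (1.48 log units; beyond the scatter), a large step where the earlier pair had shown only a modest one, so this single place on the shared core spans a wide range of numbers, and an all-carbon aryl group with no chlorine stands lowest among the three. No measurement bearing on why the number falls with this exchange is available.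

The compounds shown leave open whether the drop is particular to isopropyl or would also appear with a 4-tert-butylphenyl, 4-ethylphenyl or 4-methoxyphenyl group on the same nitrogen. They also leave open how a 4-chlorophenyl group would compare, and whether the 4-isopropylphenyl gain would hold if the carboxylic acid of the shared core gave way to a tetrazole or a primary amide.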